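The source may report more compounds than this note shows. Statements on the series, on what has been measured and on what is new or still open speak of the compounds shown alone.

Compound 3 `CCCCCCCCC#Cc1cc2cn(C)c(=O)nc2o1` gives only a limit in a functional assay on HEL cells (Homo sapiens) for cytotoxicity (on this read-out higher numbers stand for lower toxicity in this test and lower numbers for higher toxicity in this test), reported as > 175000 nM; this is the assay limit (the limit of > 175000 nM in this assay, at which 1 of the 3 values shown sits), and no number is known for it. Compound 4 `CCCCCCCCC#Cc1cc2cn([C@@H]3O[C@H](CO)[C@@H](O)[C@@H]3O)c(=O)nc2o1` carries 3,4-dihydroxy-5-(hydroxymethyl)oxolan-2-yl in place of methyl on an aromatic nitrogen. Within the data shown here, the one measured step that bears on the change is an at least 3.5-fold higher number from compound 2 to compound 3 (0.55 log units; beyond the scatter), where compound 2 `CCCCCCCCC#Cc1cc2cn([C@@H]3O[C@H](CO)[C@@H](O)[C@H]3O)c(=O)nc2o1` gave 49000 nM. Compound 1 `CCCCCCC#Cc1cc2cn([C@@H]3O[C@H](CO)[C@@H](O)[C@@H]3O)c(=O)nc2o1` shares the entering group of compound 4 but with a shorter chain; in this assay compound 1 gave 133000 nM. Compound 4 is therefore expected to return to a numeric value, the step of an at least 2.5-fold lower number from compound 3 to compound 4 (0.39 log units; beyond the scatter) being estimated as a decrease at least modest in size. The estimate for compound 4 in this assay is 70000 nM, within 30000 nM to 175000 nM.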

Compound 4, minimum cytotoxic concentration: 49000 nM
Compound 4: the middle estimate sits 1.4-fold (0.15 log units) above what was measured, within the range that was stated.
By their numbers in this assay, from the lowest: compounds 2 and 4 (each within the scatter of the next); then compound 1. At a limit, above all of these: compound 3.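

In this assay, 3,4-dihydroxy-5-(hydroxymethyl)oxolan-2-yl in place of methyl on the aromatic nitrogen gives an at least 3.5-fold lower number from compound 3 to compound 4 (0.55 log units; beyond the scatter), a step read against a limit for compound 3 and not against a number: the limit of > 175000 nM in this assay, at which 1 of the 4 values shown sits. The stereocentre at a saturated ring carbon gives no change at the digits printed from compound 2 to compound 4 (within the scatter): the fact that compounds 2 and 4 differ only in the configuration as drawn. Ethyl in place of hydrogen on a saturated chain carbon, six bonds along the chain from a triple-bonded carbon, gives a 2.7-fold lower number from compound 1 to compound 4 (0.43 log units; beyond the scatter).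

Open, as far as these compounds go, is whether a chain longer than that of compound 4 would lower the number further. Also open, from the compounds shown here alone, is whether 2-hydroxyethyl on the aromatic nitrogen would give a numeric value or stay at the limit.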